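The compounds below may be only part of what the source reports. "The series", "measured", "known", "first", "only" and "open" are said of these compounds alone.

Measured compounds:
Compound 1, `CCCOc1cc(C(F)(F)F)ccc1CNC(=O)C(C)c1ccc(NS(C)(=O)=O)c(F)c1`, 2 nM
Compound 2, `CC(C(=O)NCc1ccc(C(F)(F)F)cc1OCc1ccc(F)cc1)c1ccc(NS(C)(=O)=O)c(F)c1`, 0.5 nM
Compound 3, `CC(C(=O)NCc1ccc(C(F)(F)F)cc1SCc1ccccc1)c1ccc(NS(C)(=O)=O)c(F)c1`, 0.5 nM

All three were tested in an assay on CHO cells for antagonist activity at transient receptor potential cation channel subfamily V member 1 (Homo sapiens), read by FLIPR; a lower number here means a stronger inhibitor, a higher number a weaker inhibitor. Compound 3 stands level with compound 2 at the digits given, and the two together hold the lowest numbers of the three; its furthest neighbour is compound 1, which is a 4.0-fold lower number from compound 1 to compound 3 (0.60 log units; beyond the scatter). Compound 4, `CC(C(=O)NCc1ccc(C(F)(F)F)cc1[N+](=O)[O-])c1ccc(NS(C)(=O)=O)c(F)c1`, has not yet been measured. It differs from compound 3 in one place: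

nitro in place of benzylsulfanyl on an aromatic carbon

Among the compounds with values here, two measured steps bear on this change. Going a 4.0-fold lower number from compound 1 to compound 2 (0.60 log units; beyond the scatter) and going a 4.0-fold lower number from compound 1 to compound 3 (0.60 log units; beyond the scatter), the gain came each time when a group carrying a six-membered aromatic ring of carbon only took the place of a plain chain at this position; the step of no change at the digits printed from compound 2 to compound 3 (within the scatter) shows that exchanging one such ring-bearing group for another made no difference. Compound 4 removes the ring-bearing group entirely, so the direction is expected to run back toward compound 1 or somewhat beyond it. Compound 4 is therefore expected to give 5 nM, within 1.5 nM to 20 nM, a step of a 10-fold higher number from compound 3 to compound 4 (1.00 log units; beyond the scatter) in this assay.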

Compound 4, inhibition constant: "not active" (no number reported)
The entry for compound 4 holds no number, so the estimate cannot be set against anything.
By their numbers in this assay, from the lowest: compounds 2 and 3 (each within the scatter of the next); then compound 1.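

Within the data shown here, compound 4 is reported in this assay as "not active", with no number, so no step from compound 2, compound 3 or compound 1 to compound 4 can be read. No evidence on hand accounts for this entry. The compounds shown leave open how large the change is when nitro takes the place of benzylsulfanyl.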